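Does flipping one double bond change a limit?

The source may hold more compounds than are shown below. What is called first, only, known or untested is meant among the compounds shown, and "the series" means these compounds.

Compound 1 `CCOC(=O)C1=C(C)NC(=S)NC1c1cccc(OCCCCOc2cccc(C3NC(=S)NC(C)=C3C(=O)OCC)c2)c1`: > 200 ug/mL (a limit)
Compound 2 `COC(=O)[C@@H]1CCCN1C(=O)C1=C(C)NC(=S)NC1c1cccc(OC/C=C\COc2cccc(C3NC(=S)NC(C)=C3C(=O)N3CCC[C@H]3C(=O)OC)c2)c1`: > 200 ug/mL (a limit)

Both compounds were tested in a functional assay on A549 cells (Homo sapiens) for cytotoxicity, read by MTT assay, with a stated time of 48 h (a higher number here means a weaker inhibitor, a lower number a stronger inhibitor), and neither gave an exact number. The two results sit together at one ceiling (the limit of > 200 ug/mL in this assay, at which 2 of the 2 values shown sit) so no order can be drawn between them.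

Compound 2 stands at a limit of the assay (> 200 ug/mL) and this is not a number.

Compound 3 `COC(=O)[C@@H]1CCCN1C(=O)C1=C(C)NC(=S)NC1c1cccc(OC/C=C/COc2cccc(C3NC(=S)NC(C)=C3C(=O)N3CCC[C@H]3C(=O)OC)c2)c1` is the next to be tested. Its change from compound 2 is small (the two compounds have the same atoms and bonds; at least one stereo element is drawn with a configuration in one of them and without one in the other: 1 of 5 stereo elements differ; a double bond is drawn Z in compound 2 and E in compound 3): the two compounds have the same atoms and bonds, and a double bond is drawn Z in compound 2 and E in compound 3.

For the measured compounds named here, no measured step between two compounds is available as a guide. The estimated step (a number no higher from compound 2 to compound 3 (the limit leaves the size open)) in this assay is none beyond the scatter, in either direction. This expectation rests only on the shared ceiling of the two measured compounds (the limit of > 200 ug/mL in this assay, at which 2 of the 2 values shown sit) and on how little the structure changes.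

The estimate for compound 3 is 200 ug/mL (expected range 120 ug/mL to 320 ug/mL) and the assay may well report only a limit again.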

Compound 3, half-maximal inhibitory concentration: 148 ug/mL
Beside the measured number, compound 3's estimate is 1.4-fold (0.13 log units) above it; the measured number falls inside the stated range.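

In this assay, compound 3 is the only compound shown with an exact number, which makes this double bond the one place where a change lifts a result off the ceiling shared by the others: the limit of > 200 ug/mL in this assay, at which 2 of the 3 values shown sit. Turning the double bond from Z to E gives an at least 1.3-fold lower number from compound 2 to compound 3 (0.13 log units; that floor lies within the scatter). As far as these compounds go, the result for compound 2 is a limit and not a number, so the true size of this step stays open: it may be no more than ordinary scatter, or it may be much larger.

The compounds shown leave open whether a longer chain carrying the same E double bond, or a free carboxylic acid in place of the methyl ester, would shift the number further in this assay. Any reading of the E and Z shapes also carries a caution about how the two structures are drawn: the fact that one of compounds 2 and 3 is drawn with a defined configuration and the other without, at the place where they differ.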